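From fluoro to hydroxymethyl on an aromatic carbon

This account rests on a few compounds, and the source may have more. Where it says the series, first, only, none or still open, it means among the compounds named here.

In a functional assay on HeLa cells (Homo sapiens) for inhibition (on this read-out higher numbers stand for weaker inhibition and lower numbers for stronger inhibition), compound 1 `Cc1cn(/C=C/C=O)c(=O)[nH]c1=O` gives 25000 nM and compound 2 `O=C/C=C/n1cc(F)c(=O)[nH]c1=O` gives 40000 nM. Within the data shown here, these two values lie within the scatter of each other, and they are the only two actual numbers in the set. Compound 3 `Cc1cn(/C=C/C#N)c(=O)[nH]c1=O` reports a limit of the assay, > 100000 nM. Cyano in place of formyl on the chain gives an at least 4.0-fold higher number from compound 1 to compound 3 (0.60 log units; beyond the scatter), but that change lies away from the aromatic carbon at issue here.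

Compound 4 `O=C/C=C/n1cc(CO)c(=O)[nH]c1=O` has not yet been measured. It carries hydroxymethyl in place of fluoro on an aromatic carbon relative to compound 2: hydroxymethyl in place of fluoro on an aromatic carbon. Among the measured compounds shown here, only one measured step touches that aromatic carbon, fluoro in place of methyl: a 1.6-fold higher number from compound 1 to compound 2 (0.20 log units; within the scatter). Hydroxymethyl itself has not been tested at this carbon, so that single small step is a thin guide. An estimated 1.1-fold higher number from compound 2 to compound 4 (0.05 log units; within the scatter) is expected in this assay, which means no step beyond the scatter. Compound 4 is expected at 45000 nM, with an estimated range of 18000 nM to 100000 nM.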

Compound 4, half-maximal inhibitory concentration: > 100000 nM
Compound 4 was reported as a limit (the forecaster's own chance of this, stated with the estimate: 15%); middle value at least 2.2-fold (0.34 log units) away from the limit.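

In this assay compound 4 gives > 100000 nM, which is a limit of the assay and not a number. Among these compounds, the earlier swap at this aromatic carbon, between methyl and fluoro, stayed within the scatter, whereas hydroxymethyl is the first group here to move the read-out beyond it, with an at least 2.5-fold higher number from compound 2 to compound 4 (0.39 log units; beyond the scatter). The change need be no larger than a hydroxy in place of hydrogen on the saturated chain carbon bound to the aromatic carbon, which gives an at least 4.0-fold higher number from compound 1 to compound 4 (0.60 log units; beyond the scatter).

Going by these compounds, how much weaker compound 4 really is remains open, as does its order relative to compound 3: the limit of > 100000 nM in this assay, at which 2 of the 4 values shown sit. Also open is whether an amine, a carboxylic acid or a longer chain at this aromatic carbon would follow hydroxymethyl or stay with methyl and fluoro.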